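Swapping a carbamoylphenyl for a pyridyl on the benzylic arm

The source may report more compounds than this note shows. Statements on the series, on what has been measured and on what is new or still open speak of the compounds shown alone.

Measured compounds:
- compound 1, `COc1ccc(-c2c(C)nc3c(NCC4CCOCC4)cc(C)cn23)cc1OC`: 6
- compound 2, `COc1ccc(-c2c(C)nc3c(NCc4ccc(C(N)=O)cc4)nc(C)cn23)cc1OC`: 3.9

Among the measured compounds shown here, compound 1 and compound 2 share the same dimethoxyphenyl-bearing core and differ in several places at once, so no single structural step links them. In a physicochemical assay for lipophilicity, at pH 7.4 (on this read-out lower numbers stand for lower lipophilicity and higher numbers for higher lipophilicity), compound 1 gives 6 and compound 2 gives 3.9; compound 2 stands lowest of the two numbers, and the gap to compound 1 is beyond the scatter of the measurement.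

Compound 3, `COc1ccc(-c2c(C)nc3c(NCc4cccnc4)nc(C)cn23)cc1OC`, is not yet measured. It differs from compound 2 in one place: pyridin-3-yl in place of 4-carbamoylphenyl on a saturated chain carbon bound to a nitrogen on an aromatic ring. For the measured compounds named here, no measured pair shows the effect of this change on its own. Both the leaving group and the entering group carry a hydrogen-bond acceptor, while a hydrogen-bond donor is lost, so the expected step from compound 2 to compound 3 in this assay is a number 0.10 log units higher from compound 2 to compound 3 (within the scatter), a change that is expected not to exceed the usual scatter. Compound 3 is therefore expected to give about 4, within a range from 3.4 to 4.6.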

Compound 3, distribution coefficient: 4.5
Compound 3: middle estimate off by 0.50 log units, on the low side, within the range that was stated.
By their numbers in this assay, from the lowest: compound 2; then compound 3; then compound 1.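

In this assay, among the compounds shown here, the first single-place comparison on this arm gives a number 0.60 log units higher from compound 2 to compound 3 (beyond the scatter), so this swap on its own moves the number by more than repeat measurements would. The change alters several things at once: the entering pyridin-3-yl is smaller than the leaving 4-carbamoylphenyl, has a hetero atom in its ring and carries no hydrogen-bond donor, so this single step cannot show which of these differences counts. Nothing measured here explains the size or direction of the step.

The compounds shown leave open what an unsubstituted phenyl, which has neither the carbamoyl group nor the ring nitrogen, would give at this place. They also leave open how pyridin-2-yl, pyridin-4-yl or a 4-carboxyphenyl group would compare with these two groups.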